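Benzyl substituent series: solubility at the assay limit

A few compounds are considered here, and "the series" means these few. Any claim that something is new, unique, unknown or untested is made for them only; others in the source may bear on it.

Measured so far:
compound 1 `Cc1noc(-c2nc(C)c3c(c2N)C(=O)N(Cc2ccccc2)C3=O)n1` — < 5000 nM
compound 2 `Cc1noc(-c2nc(C)c3c(c2N)C(=O)N(Cc2ccc(-c4ccncc4)cc2)C3=O)n1` — < 5000 nM
compound 3 `Cc1noc(-c2nc(C)c3c(c2N)C(=O)N(Cc2ccc(OC(F)F)cc2)C3=O)n1` — < 5000 nM

Compounds 1, 2 and 3 share one core and differ only in the group on the benzyl ring. In a physicochemical assay for solubility, using the shake flask method, in simulated intestinal fluid, measured as kinetic solubility, with a stated time of 2 h, at 25 degrees C, at pH 6.5 (a lower number here means a less soluble compound, a higher number a more soluble compound), compound 1 gives < 5000 nM, which is a limit of the assay and not a number. In this assay compound 2 likewise gives < 5000 nM, a limit. In this assay compound 3 also gives < 5000 nM, again a limit. Accordingly the steps a step that the two limits leave unreadable from compound 1 to compound 2, a step that the two limits leave unreadable from compound 1 to compound 3 and a step that the two limits leave unreadable from compound 2 to compound 3 cannot be read; all three values sit at the limit of < 5000 nM in this assay, at which 3 of the 3 values shown sit, so compound 2 stands at the limit with the other two and no ranking is possible.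

Compound 4 `Cc1noc(-c2nc(C)c3c(c2N)C(=O)N(Cc2ccc(S(C)(=O)=O)cc2)C3=O)n1` is to be measured in this assay. It differs from compound 2 as follows: methylsulfonyl in place of pyridin-4-yl on an aromatic carbon. Within the data shown here, no measured step bears on this change, and the three limits give no direction or size to expect; the working expectation is that compound 4 remains near the limit. Compound 4 is therefore estimated at 4000 nM, range 1000 nM to 15000 nM, implying an expected step that the limit leaves unreadable from compound 2 to compound 4.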

Compound 4, solubility: < 5000 nM
Compound 4 was reported as a limit; the forecaster's own chance of this, stated with the estimate: 60%; the middle value is on the limit's open side.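

In this assay compound 4 gives < 5000 nM, a limit of the assay and not a number. No step between compound 4 and compounds 1, 2 or 3 can be read: the limit of < 5000 nM in this assay, at which 4 of the 4 values shown sit.

The compounds shown leave open whether hydrogen, pyridin-4-yl, difluoromethoxy and methylsulfonyl on the benzyl ring differ at all in this assay.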